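The source may hold more compounds than are shown below. What is called first, only, known or untested is meant among the compounds shown, and "the series" means these compounds.

Measured compounds:
compound 1, `Cc1c(C)c2c(c(C)c1O)CC[C@@](C)(CC(=O)O)O2`, 17000 nM
compound 2, `Cc1c(C)c2c(c(C)c1O)CC[C@](C)(CCN(C)C)O2`, 1000 nM

In a functional assay (brain) for inhibition, with Rattus norvegicus as the target (a lower number here means a stronger inhibitor, a higher number a weaker inhibitor), compound 2 holds the lower of the two numbers, and compound 1 stands a good deal higher, a gap that lies beyond the usual scatter. Compound 3, `Cc1c(C)c2c(c(C)c1O)CC[C@](C)(CC(=O)O)O2`, has not yet been measured in this assay. It differs from compound 2 in one place: carboxy in place of (dimethylamino)methyl on a saturated chain carbon bound to a saturated ring carbon. No step between measured compounds of exactly this kind is available, so the expectation for compound 3 rests on the two numbers shown. For the measured compounds named here, compound 1 also carries a carboxy group on its side chain and gives 17000 nM in this assay, which is the only guide to how such a change may read. Compound 3 is therefore expected to be a weaker inhibitor than compound 2, with a step from a 12-fold higher number from compound 2 to compound 3 (1.08 log units; beyond the scatter) that is estimated to lie well beyond the scatter. For compound 3 the estimated value in this assay is 12000 nM, with a range from 3000 nM to 50000 nM.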

Compound 3, half-maximal inhibitory concentration: 14000 nM
Estimate against measurement, compound 3: 1.2-fold (0.07 log units) below, and the stated range covers the measured number.
By their numbers in this assay, from the lowest: compound 2; then compounds 3 and 1 (each within the scatter of the next).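

In this assay, the exchange of (dimethylamino)methyl for carboxy on a saturated chain carbon bound to a saturated ring carbon can now be read as a single change, and it is a large one: a 14-fold higher number from compound 2 to compound 3 (1.15 log units; beyond the scatter). This ties the gap to the side chain itself, with the configuration at the ring carbon held as drawn in compound 2. The second step answers a separate question that the earlier compounds could not address, since the pair carrying carboxymethyl shows no difference beyond the scatter, with a 1.2-fold lower number from compound 1 to compound 3 (0.08 log units; within the scatter), and this reading isolates the configuration at that one stereocentre: the fact that compounds 1 and 3 differ only in the configuration as drawn

The compounds shown leave open whether the configuration at the ring carbon matters as little with 2-(dimethylamino)ethyl on the chain as it does with carboxymethyl. They also cannot separate the contribution of the nitrogen from that of its two methyl groups or of the chain length, a question that a primary amine, a pyrrolidine, a primary amide or a longer chain ending in a carboxylic acid at the same place would bear on.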